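Swapping a Five-Membered Ring on the Shared Core

A few compounds are considered here, and "the series" means these few. Any claim that something is new, unique, unknown or untested is made for them only; others in the source may bear on it.

Of the compounds shown here, two have been measured so far. Compound 1 `COc1ncnc2c1c(-c1ccsc1)cn2[C@@H]1O[C@H](CO)[C@@H](O)[C@H]1O` carries a thiophen-3-yl group, and in a functional assay on HL-60 cells (Homo sapiens) for antiproliferative activity, read by XTT assay, with a stated time of 72 h (a lower number here means a stronger inhibitor, a higher number a weaker inhibitor), compound 1 gives 130 nM. Compound 2 `COc1ncnc2c1c(-c1ccoc1)cn2[C@@H]1O[C@H](CO)[C@@H](O)[C@H]1O` differs only in bearing furan-3-yl at the same aromatic carbon; in this assay compound 2 gives 150 nM. The step of a 1.2-fold higher number from compound 1 to compound 2 (0.06 log units; within the scatter) lies within the scatter, so the two numbers cannot be told apart. On the numbers shown, compound 2 has the higher of the two values, with compound 1 nearest to it, but that gap is within the scatter.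

Compound 3 `COc1ncnc2c1c(-c1cccs1)cn2[C@@H]1O[C@H](CO)[C@@H](O)[C@H]1O` is not yet measured. Its change from compound 2 is thiophen-2-yl in place of furan-3-yl on an aromatic carbon. Going by the values given here, only one measured step bears on this move: the exchange of sulfur for oxygen in the five-membered ring, seen in a 1.2-fold higher number from compound 1 to compound 2 (0.06 log units; within the scatter), which was within the scatter. Among the compounds with values here, no measured pair shows thiophen-2-yl against thiophen-3-yl, so that part of the change is untested. Within the data shown here, with the one relevant step so small, no step beyond the scatter is expected in this assay. Compound 3 is therefore expected to give 130 nM, with a range from 60 nM to 300 nM. That corresponds to an expected step of a 1.2-fold lower number from compound 2 to compound 3 (0.06 log units; within the scatter).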

Compound 3, half-maximal inhibitory concentration: 80 nM
Beside the measured number, compound 3's estimate is 1.6-fold (0.21 log units) above it; the measured number falls inside the stated range.
By their numbers in this assay, from the lowest: compounds 3, 1 and 2 (each within the scatter of the next).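

Going by these compounds alone, what these numbers add is the first look at where the ring is attached, not only which hetero atom it carries. In this assay, thiophen-2-yl in place of thiophen-3-yl on this aromatic carbon of the shared core gives a 1.6-fold lower number from compound 1 to compound 3 (0.21 log units; within the scatter), so the two ways of attaching a thiophene cannot be told apart here. The change that alters both the hetero atom and the attachment gives a 1.9-fold lower number from compound 2 to compound 3 (0.27 log units; within the scatter), so in this small set no swap among these three rings has yet moved the number beyond the scatter, and nothing available accounts for the small differences seen.

From the compounds shown here alone, all three groups are five-membered aromatic rings with one hetero atom, so it remains open whether this carbon accepts something of a different kind, such as a phenyl ring, a five-membered ring with two hetero atoms, an amine or a longer alkyl chain. Furan-2-yl would complete the set of four rings, giving an oxygen counterpart to thiophen-2-yl and a second direct comparison of the two attachments.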